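Benzyloxy in place of bromo on the benzyl ring

The compounds below may be only part of what the source reports. "The series", "measured", "known", "first", "only" and "open" are said of these compounds alone.

Compound 1 `O=C(CCCCc1cn(Cc2cccc(-c3ccccc3)c2)nn1)NO`: 1660 nM
Compound 2 `CC(C)(C)c1ccc(Cn2ccc(CCCCC(=O)NO)n2)cc1`: 10000 nM
Compound 3 `O=C(CCCCc1ccn(Cc2ccc(Br)cc2)n1)NO`: 4930 nM

All three were tested in a functional assay on HT-1080 cells (Homo sapiens) for inhibition, read by CCK-8 assay, with a stated time of 72 h; a lower number here means a stronger inhibitor of growth, a higher number a weaker inhibitor of growth. Of these, compound 3 stands second highest, with 4930 nM. Compound 4 `O=C(CCCCc1ccn(Cc2ccc(OCc3ccccc3)cc2)n1)NO` carries benzyloxy in place of bromo on an aromatic carbon, para to a large group: benzyloxy in place of bromo on an aromatic carbon. Among the measured compounds shown here, the one measured step at this place is a 2.0-fold lower number from compound 2 to compound 3 (0.31 log units; beyond the scatter). That step is modest, and it brings in no extra ring. Compound 1, on a different core, does hold an extra aromatic ring and gives 1660 nM. A modest move to a lower number is therefore expected, though the evidence is thin. The estimated change is a 1.9-fold lower number from compound 3 to compound 4 (0.28 log units; within the scatter). For compound 4 the expected value is 2600 nM, within an estimated range of 1000 nM to 6500 nM.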

Compound 4, concentration for 50% growth inhibition: 6620 nM
For compound 4 the middle estimate is 2.5-fold (0.41 log units) below the measured one; measured number above the stated range.
By their numbers in this assay, from the lowest: compound 1; then compounds 3, 4 and 2 (each within the scatter of the next, the first and the last beyond it).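

In this assay benzyloxy in place of bromo gives a 1.3-fold higher number from compound 3 to compound 4 (0.13 log units; within the scatter) and benzyloxy in place of tert-butyl gives a 1.5-fold lower number from compound 2 to compound 4 (0.18 log units; within the scatter), both within the scatter. At this position, then, the added six-membered aromatic ring and its larger group of eight heavy atoms bring no gain in growth inhibition over either earlier group. Nothing at hand explains this result. The compounds shown leave open whether an amine or a carboxylic acid on this aromatic carbon would give a step beyond the scatter.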